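The compounds below may be only part of what the source reports. "The series", "measured", "known", "first", "only" and "open" are said of these compounds alone.

Measured compounds in a functional assay on RAW264.7 cells (Mus musculus) for inhibition; on this read-out lower numbers stand for stronger inhibition and higher numbers for weaker inhibition:

compound 1, `CC(C)(C)OC(=O)N(Cc1ccco1)C(=O)c1ccc(CN2Cc3ccccc3C2=O)cc1`, gives 51800 nM.
compound 2, `O=C(NCc1ccco1)c1ccc(CN2Cc3ccccc3C2=O)cc1`, gives 49700 nM.
compound 3, `CC(C)(C)OC(=O)N(Cc1ccco1)C(=O)c1ccc(Cn2c(=O)c3ccccc3[s+]2[O-])cc1`, gives 68000 nM.

All three sit close together in this assay. The change from compound 1 to compound 2 is hydrogen in place of tert-butoxycarbonyl on an amide-type nitrogen; the step it made was a 1.0-fold lower number from compound 1 to compound 2 (0.02 log units; within the scatter). Compound 3 carries a different core: a group of 11 heavy atoms (7 carbon, 1 nitrogen, 2 oxygen, 1 sulfur; one five-membered aromatic ring with 2 hetero atoms, one six-membered aromatic ring of carbon only) in place of a group of 10 heavy atoms (8 carbon, 1 nitrogen, 1 oxygen; one five-membered non-aromatic ring with 1 hetero atom, one six-membered aromatic ring of carbon only), on a saturated chain carbon bound to an aromatic carbon, and that change gave a 1.3-fold higher number from compound 1 to compound 3 (0.12 log units; within the scatter). Compound 3 shows the highest of the three numbers, but each of its gaps to compound 1 and compound 2 is within the scatter, so no order among them is established.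

Compound 4, `O=C(NCc1ccco1)c1ccc(Cn2c(=O)c3ccccc3[s+]2[O-])cc1`, is not yet measured. It differs from compound 3 by hydrogen in place of tert-butoxycarbonyl on an amide-type nitrogen, the same change as that from compound 1 to compound 2, made at a place described in the same words. The expectation for this assay therefore rests on that single measured pair: since the step of a 1.0-fold lower number from compound 1 to compound 2 (0.02 log units; within the scatter) was within the scatter, the step from compound 3 to compound 4 is expected to be a 1.0-fold lower number from compound 3 to compound 4 (0.02 log units; within the scatter), likewise within the scatter. Compound 4 is estimated at 65000 nM, with a range from 30000 nM to 140000 nM.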

Compound 4, half-maximal inhibitory concentration: 23300 nM
Compound 4: middle estimate off by 2.8-fold (0.45 log units), on the high side, outside the stated range (below it).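

In this assay, hydrogen in place of tert-butoxycarbonyl on the amide-type nitrogen gave a 2.9-fold lower number from compound 3 to compound 4 (0.47 log units; beyond the scatter). The same change therefore does not carry a fixed step from one core to the other in this series, and a step read on the core of compound 1 cannot simply be transferred to the core of compound 3: the same change on two cores in this assay, a 1.0-fold lower number (0.02 log units; within the scatter) from compound 1 to compound 2 and a 2.9-fold lower number (0.47 log units; beyond the scatter) from compound 3 to compound 4, 2.8-fold (0.45 log units) apart, beyond the scatter of two such steps. This rests on one pair per core, so it shows that the outcome of the change depends on the core in these four compounds, but it does not show why, nor does it give a rule for any further core.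

Still open, going by these compounds, is how other groups on the amide-type nitrogen, such as methyl or acetyl, would read on each of the two cores, and whether they would show the same difference between the cores. Also open, on these data alone, is whether an amine or a carboxylic acid on the benzylic part of the series would alter the step.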